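Replacing the 1-bromoethyl group of compound 1

The compounds below may be only part of what the source reports. "The series", "measured", "known", "first", "only" and "open" are said of these compounds alone.

Measured in a functional assay on KYSE-450 cells (Homo sapiens) for inhibition, read by MTT assay, with a stated time of 48 h (on this read-out lower numbers stand for stronger inhibition and higher numbers for weaker inhibition), the three compounds read as follows:
- compound 1 `COc1ccc(CN(C(=O)C(C)Br)c2cc(OC)c(OC)c(OC)c2)cc1O` gives 160 nM
- compound 2 `COc1ccc(CNc2cc(OC)c(OC)c(OC)c2)cc1Cl` gives 47800 nM
- compound 3 `COc1ccc(CNc2cc(OC)c(OC)c(OC)c2)cc1Br` gives 39800 nM

Compound 1 holds the lowest of the three numbers, well beyond the scatter from both others. Compound 4 `COc1ccc(CN(C(=O)CO)c2cc(OC)c(OC)c(OC)c2)cc1O` keeps the core of compound 1 and differs in one group: hydroxymethyl in place of 1-bromoethyl on a carbonyl carbon with hydroxymethyl in place of 1-bromoethyl on a carbonyl carbon.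

For the measured compounds named here, the one measured step is a 1.2-fold lower number from compound 2 to compound 3 (0.08 log units; within the scatter) and it lies within the scatter. It is a halogen exchange at another place, so it does not bear directly on this change. Compound 2 and compound 3 also differ from compound 1 in more than one place, so their gap cannot be assigned to the 1-bromoethyl group alone. Going by the values given here, no measured compound without that group has a low number, so a weaker result is expected, though only loosely. The expected step is a 16-fold higher number from compound 1 to compound 4 (1.19 log units; beyond the scatter) and would lie beyond the scatter. Compound 4 is estimated at 2500 nM with an expected range of 400 nM to 20000 nM on this thin evidence.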

Compound 4, half-maximal inhibitory concentration: 370 nM
Compound 4: middle estimate off by 6.8-fold (0.83 log units), on the high side, and the stated range ends above it.
By their numbers in this assay, from the lowest: compound 1; then compound 4; then compounds 3 and 2 (each within the scatter of the next).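

In this assay, hydroxymethyl in place of 1-bromoethyl on a carbonyl carbon gives a 2.3-fold higher number from compound 1 to compound 4 (0.36 log units; beyond the scatter), a modest step beyond the scatter. The 1-bromoethyl group is thus not needed for a low number at this position: without it, and with a hydrogen-bond donor and acceptor counted in the entering group, compound 4 still gives 370 nM. No evidence at hand accounts for the size of this step.

The single change removes the bromine and a carbon and adds the oxygen at once, so the compounds shown do not separate what each of these contributes. On these data alone, how an aminomethyl group, a chloromethyl group, a carboxylic acid or a longer chain would read on the same carbonyl carbon remains open.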